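The compounds below may be only part of what the source reports. "The series", "measured", "known", "first", "only" and "open" are said of these compounds alone.

Measured compounds:
compound 1, `CN1C(=O)C(CC2CC2)N(C)c2nc(Nc3ccc(S(N)(=O)=O)cc3)ncc21`, which in an assay on Sf9 cells for inhibition of serine/threonine-protein kinase 4 (Homo sapiens), read by luminescence and ADP-Glo, with a stated time of 1 h, in the presence of a further agent that is not named here (on this read-out lower numbers stand for stronger inhibition and higher numbers for weaker inhibition), gives 211 nM
compound 2, `CN1C(=O)C(c2ccccc2)N(C)c2nc(Nc3ccc(S(N)(=O)=O)cc3)ncc21`, which in this assay gives 383 nM
compound 3, `CN1C(=O)C(c2cccc(Cl)c2)N(C)c2nc(Nc3ccc(S(N)(=O)=O)cc3)ncc21`, which in this assay gives 989 nM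

Compound 1 has the lowest number of the three. The gap to compound 2 is a 1.8-fold higher number from compound 1 to compound 2 (0.26 log units; within the scatter), so the two cannot be ranked; the gap to compound 3 is a 4.7-fold higher number from compound 1 to compound 3 (0.67 log units; beyond the scatter). Between the two aryl compounds the step is a 2.6-fold higher number from compound 2 to compound 3 (0.41 log units; beyond the scatter).

Compound 4, `COc1ccccc1C1C(=O)N(C)c2cnc(Nc3ccc(S(N)(=O)=O)cc3)nc2N1C`, has not yet been measured in this assay. It differs from compound 1 in one place: 2-methoxyphenyl in place of cyclopropylmethyl on a saturated ring carbon. The two measured steps that exchange cyclopropylmethyl for an aryl group both bear on it. The plain phenyl of compound 2 moved the number up only within the scatter, while the 3-chlorophenyl of compound 3 gave a modest rise beyond it. A substituted phenyl is therefore expected to land above compound 1, most likely at a size between those two steps, though a result inside the scatter cannot be excluded. Compound 4 is expected to give about 520 nM, within 220 nM to 1300 nM, which corresponds to an expected step of a 2.5-fold higher number from compound 1 to compound 4 (0.39 log units; beyond the scatter).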

Compound 4, half-maximal inhibitory concentration: 251 nM
Beside the measured number, compound 4's estimate is 2.1-fold (0.32 log units) above it; the measured number falls inside the stated range.
By their numbers in this assay, from the lowest: compounds 1, 4 and 2 (each within the scatter of the next); then compound 3.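

In this assay, the saturated ring carbon accepts the 2-methoxyphenyl group in place of cyclopropylmethyl with no readable change (a 1.2-fold higher number from compound 1 to compound 4 (0.08 log units; within the scatter)), so compound 3 shows that a substituted phenyl here can carry a cost, but compound 4 shows that it need not. For the compounds shown here, the choice of substituted phenyl does matter, since exchanging 3-chlorophenyl for 2-methoxyphenyl gives a step beyond the scatter (a 3.9-fold lower number from compound 3 to compound 4 (0.60 log units; beyond the scatter)), whereas adding a methoxy group to the plain phenyl gives one within it (a 1.5-fold lower number from compound 2 to compound 4 (0.18 log units; within the scatter)), which leaves compound 3 as the only one of the aryl compounds that separates from the others. Nothing available accounts for this difference between the two substituted phenyl groups.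

The 3-chlorophenyl and 2-methoxyphenyl groups differ both in the substituent and in where it sits on the phenyl, so these compounds cannot show which of the two matters. Also open, from the compounds shown here alone, is how this position would respond to a carboxylic acid or a primary amine on the phenyl, or to a longer alkyl chain such as butyl in place of cyclopropylmethyl.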